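Ester-to-amide step on the indole acrylonitrile

A few compounds are considered here, and "the series" means these few. Any claim that something is new, unique, unknown or untested is made for them only; others in the source may bear on it.

In a functional assay on the whole organism (strain CD1) for inhibition, with Mus musculus as the target, with stated times of 15 min and 20 min, at a dose of 10 mg/kg by the subcutaneous route (on this read-out lower numbers stand for less inhibition and higher numbers for more inhibition at the one dose given (going by the name of the read-out)), compound 1 `O=C(O)/C(F)=C/c1ccccc1` gives 34%, and compound 2 `CCOC(=O)/C(C#N)=C/c1cc2ccccc2[nH]1` gives 88.4%, the higher of the two numbers shown, with compound 1 as its only neighbour a gap beyond the scatter away. Going by the values given here, no pair of measured compounds differs in one place, so no single step has been measured. Compound 3 `N#C/C(=C\c1cc2ccccc2[nH]1)C(=O)NC1CCCCC1` carries one change against compound 2: cyclohexylamino in place of ethoxy on a carbonyl carbon. Nothing measured speaks to this change, so a step of modest size, probably within the scatter, is expected: a number 8.4 percentage points lower from compound 2 to compound 3 (within the scatter). For compound 3 the estimate in this assay is 80%, with a range from 55% to 95%.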

Compound 3, a percentage reported as inhibition, in the whole organism at one dose (the size of the read-out at that dose, not a potency): 45%
The estimate for compound 3 lay 35 percentage points above the measured number; measured number below the stated range.
By their numbers in this assay, from the lowest: compound 1; then compound 3; then compound 2.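

In this assay the first measured single change shows that this position is not neutral: cyclohexylamino in place of ethoxy on a carbonyl carbon gives a large step (a number 43.4 percentage points lower from compound 2 to compound 3 (beyond the scatter)) and so costs much of the inhibition at the one dose. Nothing measured here accounts for this step.

The amide hydrogen and the cyclohexyl ring enter together, so their shares stay unseparated. Open too, on these data alone, is how a methylamino group, a dimethylamino group or a carboxylic acid on the same carbonyl carbon would read out.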